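A Trichloroethyl Carbamate Judged From Three Measured Analogues

The source may hold more compounds than are shown below. What is called first, only, known or untested is meant among the compounds shown, and "the series" means these compounds.

Compound 1, `C[C@@H]1CN(C(=O)c2nc(Nc3cc(C4CC4)[nH]n3)c3cc(Cl)ccc3n2)CCN1C(=O)OC(C)(C)C`, gives 36.4% in an assay for inhibition of serine/threonine-protein kinase PAK 4 (Homo sapiens), read by FRET and Z'-LYTE, with a stated time of 60 min, tested at 50 uM, in the presence of a further agent that is not named here; a lower number here means a weaker effect, a higher number a stronger effect of the compound at the concentration tested.
Compound 2, `CC(OC(=O)N1CCN(C(=O)c2nc(Nc3cc(C4CC4)[nH]n3)c3cc(Cl)ccc3n2)C[C@H]1C)OC(=O)C(C)(C)C`, gives 65.3% in this assay.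
Compound 3, `CCCCCOC(=O)N1CCN(C(=O)c2nc(Nc3cc(C4CC4)[nH]n3)c3cc(Cl)ccc3n2)C[C@H]1C`, gives 32.7% in this assay.

Compound 3 stands lowest of the three numbers, yet its nearest neighbour, compound 1, lies within the scatter of it; only compound 2 stands clearly above it. Compound 4, `C[C@@H]1CN(C(=O)c2nc(Nc3cc(C4CC4)[nH]n3)c3cc(Cl)ccc3n2)CCN1C(=O)OCC(Cl)(Cl)Cl`, differs from compound 3 by trichloromethyl in place of butyl on a saturated chain carbon bound to an oxygen next to a carbonyl group; cut one bond further out, the change reads pentyl to 2,2,2-trichloroethyl. Within the data shown here, none of the measured steps introduces chlorine at this place, so none bears on it directly. The step of a number 3.7 percentage points lower from compound 1 to compound 3 (within the scatter) shows that swapping one alkyl chain on the carbamate oxygen for another left the number where it was, whereas a number 28.9 percentage points higher from compound 1 to compound 2 (beyond the scatter) and a number 32.6 percentage points lower from compound 2 to compound 3 (beyond the scatter) show that only the much longer chain of compound 2 moved it beyond the scatter. Compound 4 keeps a chain of the same length as compound 3, so no step beyond the scatter is expected in this assay. For compound 4 a number of 36% is therefore expected, between 15% and 60%, an expected step of a number 3.3 percentage points higher from compound 3 to compound 4 (within the scatter).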

Compound 4, a percentage reported as inhibition, at one concentration (the size of the read-out at that concentration, not a potency): 82.8%
For compound 4 the middle estimate is 46.8 percentage points below the measured one; measured number above the stated range.
By their numbers in this assay, from the lowest: compounds 3 and 1 (each within the scatter of the next); then compound 2; then compound 4.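

In this assay, the group on an oxygen next to a carbonyl group proved able to move the number far with no change in heavy-atom count: trichloromethyl in place of butyl gave a number 50.1 percentage points higher from compound 3 to compound 4 (beyond the scatter), and 2,2,2-trichloroethyl in place of tert-butyl gave a number 46.4 percentage points higher from compound 1 to compound 4 (beyond the scatter). The much larger 1-(((tert-butyl)carbonyl)oxy)ethyl no longer marks the top of the series, since 2,2,2-trichloroethyl in its place gave a number 17.5 percentage points higher from compound 2 to compound 4 (beyond the scatter), so size alone does not order these compounds. No measurement shown offers a reason for these steps.

From the compounds shown here alone, how a 2-chloroethyl or a 2,2,2-trifluoroethyl group would stand at this place remains open, and with it how much of the rise goes with the full set of three chlorine atoms. Going by these compounds, whether the change would hold as a potency, rather than as a read-out at one concentration, also stays open.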